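Shortening an Alkoxy Chain and Expected Cytotoxicity

This account rests on a few compounds, and the source may have more. Where it says the series, first, only, none or still open, it means among the compounds named here.

Within the data shown here, compound 2 `CCCOc1cc(C#N)cc(OC)c1Oc1nc(Nc2ccc(C#N)cc2)nc2ccccc12` is one of two compounds measured in an ADME assay on MT4 cells (Homo sapiens) for cytotoxicity, read by MTT assay, with a stated time of 4 days (a higher number here means that more compound is tolerated, a lower number that less compound is tolerated), and in this assay compound 2 gives 5200 nM, the only plain number among the two values shown. Compound 1 `COc1cc(C#N)ccc1Oc1nc(Nc2ccc(C#N)cc2)nc2ccccc12` reaches only a limit of this assay, >= 140000 nM. Among the measured compounds shown here, compound 1 and compound 2 differ at one place, and the step of an at least 26-fold lower number from compound 1 to compound 2 (1.43 log units; beyond the scatter) is the only measured step that bears on what follows; that step rests on the limit (the limit of >= 140000 nM in this assay, at which 1 of the 2 values shown sits). Compound 3 `COc1cc(C#N)cc(OC)c1Oc1nc(Nc2ccc(C#N)cc2)nc2ccccc12` is not yet measured. It differs from compound 2 by hydrogen in place of ethyl on a saturated chain carbon bound to an oxygen on an aromatic ring. The change runs the measured step partway back: from a propoxy group to a shorter alkoxy group rather than to hydrogen. The author therefore expects a step in this assay in the opposite direction to the measured one, toward a higher number, but smaller than the measured step. The expected step from compound 2 is a 5.8-fold higher number from compound 2 to compound 3 (0.76 log units; beyond the scatter). For compound 3 the estimate in this assay is 30000 nM, with a range from 8000 nM to 140000 nM.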

Compound 3, half-maximal cytotoxic concentration: 194000 nM
The estimate for compound 3 lay 6.5-fold (0.81 log units) below the measured number; the whole stated range lies below it.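

In this assay the change from propoxy to methoxy gives a 37-fold higher number from compound 2 to compound 3 (1.57 log units; beyond the scatter), so the length of the chain on this oxygen matters on its own. The earlier pair showed only that propoxy in place of hydrogen on an aromatic carbon goes with a lower number, which could not separate the presence of an alkoxy group at that place from the length of its chain; compound 3 keeps an alkoxy group there and does not share the low number of compound 2, so the presence of such a group does not by itself bring that number. The step from compound 1 to compound 3 cannot be read, since compound 1 gives only a limit of the assay: the limit of >= 140000 nM in this assay, at which 1 of the 3 values shown sits.

Only methoxy and propoxy stand at this place, so the compounds shown leave open how the number runs between these two chains, whether ethoxy would lie near one of them or midway. They also leave open whether a longer chain such as butoxy would bring the number lower still, and what an amine or a carboxylic acid at the end of the chain would do.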